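The source may report more compounds than this note shows. Statements on the series, on what has been measured and on what is new or still open speak of the compounds shown alone.

Measured so far:
compound 1, `Cc1cc(=O)n(-c2ccc(Br)cc2F)nc1C(=O)Nc1ccc(Oc2ncnc3[nH]ccc23)c(F)c1`, 13300 nM
compound 2, `Cc1cc(=O)n(-c2ccc(Br)cc2F)nc1C(=O)Nc1ccc(Oc2ncnc3c2ccn3C)c(F)c1`, 6670 nM

In a functional assay on PC-3 cells (Homo sapiens) for cytotoxicity, read by MTT assay, with a stated time of 72 h (a lower number here means a stronger inhibitor, a higher number a weaker inhibitor), compound 2 gives the lower of the two numbers, though the step of a 2.0-fold lower number from compound 1 to compound 2 (0.30 log units; within the scatter) lies within the scatter. Compound 3 `Cc1cc(=O)n(-c2ccccc2C(F)(F)F)nc1C(=O)Nc1ccc(Oc2ncnc3c2ccn3C)c(F)c1` differs from compound 2 in that (2-(trifluoromethyl)phenyl in place of 4-bromo-2-fluorophenyl on an aromatic nitrogen). Going by the values given here, no measured step bears on this change: the single step seen, a 2.0-fold lower number from compound 1 to compound 2 (0.30 log units; within the scatter), touched a different part of the shared core and stayed within the scatter. With nothing pointing either way, no step beyond the scatter is expected. Compound 3 is therefore estimated at 7000 nM, within a range from 2000 nM to 25000 nM, an expected step of a 1.0-fold higher number from compound 2 to compound 3 (0.02 log units; within the scatter).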

Compound 3, half-maximal inhibitory concentration: 25900 nM
For compound 3 the middle estimate is 3.7-fold (0.57 log units) below the measured one; measured number outside the range, above it.
By their numbers in this assay, from the lowest: compounds 2, 1 and 3 (each within the scatter of the next, the first and the last beyond it).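

On an aromatic nitrogen, the aryl group matters: in this assay, 2-(trifluoromethyl)phenyl in place of 4-bromo-2-fluorophenyl gives a 3.9-fold higher number from compound 2 to compound 3 (0.59 log units; beyond the scatter), a modest weakening. This is the first step shown that lies beyond the scatter, so this position responds to what it carries. No data shown here say why the number rose.

The bromine and fluorine leave and the trifluoromethyl enters in a single step, so the share of each remains unresolved. On these data alone, how an unsubstituted phenyl or an aryl group bearing an amine would read at this position also remains open.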